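The compounds below may be only part of what the source reports. "The series", "measured", "known", "first", "only" and "open" are said of these compounds alone.

In a functional assay (Nicotiana tabacum) (on this read-out lower numbers stand for stronger inhibition and higher numbers for weaker inhibition), three compounds sharing one core have been measured. Compound 1 `CCCCCCCNc1nc(SC)nc2ncccc12` gives 4070 nM, compound 2 `C=CCNc1nc(SC)nc2ncccc12` gives 400 nM, and compound 3 `CSc1nc(Nc2ccc(Cl)cc2)c2cccnc2n1` gives 8510 nM, the highest of the three numbers. Compound 4 `COc1ccc(Nc2nc(SC)nc3ncccc23)cc1` differs from compound 3 in one place, with methoxy in place of chloro on an aromatic carbon, para to a large group (methoxy in place of chloro on an aromatic carbon).

Among the measured compounds shown here, only one measured step links two compounds that differ in one place: a 10-fold lower number from compound 1 to compound 2 (1.01 log units; beyond the scatter), a large step. That step swaps vinyl for hexyl on a saturated chain, not a group on an aromatic ring, so it bears only indirectly on this change. It does show that one change can move the numbers widely, so the range is kept broad. For the measured compounds named here, no measured pair exchanges chloro or methoxy. In this assay, no step beyond the scatter is therefore expected, and neither direction is clearly favoured. The estimated step is a 1.1-fold lower number from compound 3 to compound 4 (0.05 log units; within the scatter). For compound 4 the expected value is 7500 nM, with an estimated range from 2000 nM to 25000 nM.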

Compound 4, half-maximal inhibitory concentration: 9420 nM
Compound 4: middle estimate off by 1.3-fold (0.10 log units), on the low side, within the range that was stated.
By their numbers in this assay, from the lowest: compound 2; then compound 1; then compounds 3 and 4 (each within the scatter of the next).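

In this assay, among the compounds shown here, replacing chloro with methoxy on an aromatic carbon, para to a large group, gives a 1.1-fold higher number from compound 3 to compound 4 (0.04 log units; within the scatter), the first directly measured exchange at this position. Unlike a 10-fold lower number from compound 1 to compound 2 (1.01 log units; beyond the scatter), which lies beyond the scatter and involves a saturated chain, this step lies within the scatter, so the read-out does not separate these two groups here, even though methoxy brings a hydrogen-bond acceptor that chloro lacks. Nothing available explains why the exchange leaves the number essentially unchanged.

The compounds shown leave open whether an amine, a carboxylic acid or a nitrile on the same aromatic carbon would produce a step beyond the scatter. They also do not show whether methoxy and chloro would remain indistinguishable on another carbon of that ring.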